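This account rests on a few compounds, and the source may have more. Where it says the series, first, only, none or still open, it means among the compounds named here.

The compounds here share a common core, a five-membered ring holding one nitrogen and one sulfur, and they were tested in a functional assay on HOS-TE85 cells (Homo sapiens) for inhibition, read by CCK-8 assay, with a stated time of 72 h; on this read-out lower numbers stand for stronger inhibition and higher numbers for weaker inhibition. Compound 1, `COc1ccccc1N1C(=O)CSC1C(=O)NCCCCc1ccccc1`, carries the amide directly on that core; in this assay compound 1 reaches only the assay limit of > 1000 nM, and so no number is known for it, a point recorded as the limit of > 1000 nM in this assay, at which 1 of the 3 values shown sits. Compound 2, `O=C(NCCCCc1ccccc1)c1cccc(C2SCC(=O)N2c2ccccc2)c1`, places a phenyl ring between the core and the amide; in this assay compound 2 gives 15.9 nM, the lowest of the two numbers measured. Compound 3, `O=C(NCCCCn1cccn1)c1cccc(C2SCC(=O)N2c2cccc(C3CC3)c2)c1`, with a cyclopropyl group on the aromatic ring at the ring nitrogen and a pyrazole ending the chain, gives 299 nM in this assay, a higher number that lies beyond the usual scatter.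

Compound 4, `COc1c(F)cccc1N1C(=O)CSC1c1cccc(C(=O)NCCCCc2ccccc2)c1`, is built from compound 2 by a single change: 3-fluoro-2-methoxyphenyl in place of phenyl on an amide-type nitrogen in a ring. Within the data shown here, no measured pair shows this exact change, so its effect must be guessed from the neighbours. The added substituents make the group on the ring nitrogen larger, and the only measured variation at that position, compound 3, runs to a weaker result. The step from compound 2 to compound 4 is therefore expected to be a modest loss, a 2.8-fold higher number from compound 2 to compound 4 (0.45 log units; beyond the scatter). Compound 4 is estimated at 45 nM, within a range from 12 nM to 200 nM.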

Compound 4, half-maximal inhibitory concentration: 26.2 nM
Compound 4: middle estimate off by 1.7-fold (0.23 log units), on the high side, and the stated range covers the measured number.
By their numbers in this assay, from the lowest: compounds 2 and 4 (each within the scatter of the next); then compound 3. At a limit, above all of these: compound 1.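

In this assay, 3-fluoro-2-methoxyphenyl in place of phenyl on an amide-type nitrogen in a ring gives a 1.6-fold higher number from compound 2 to compound 4 (0.22 log units; within the scatter), so this larger aromatic group, which also brings a hydrogen-bond acceptor, can stand at this position without a shift beyond the usual scatter of repeated measurements. The earlier compounds shown here could not show this: compound 3 also carries a different group here, but it differs from compound 2 at the chain end as well, so it cannot isolate this position. Among these compounds, nothing measured on these compounds accounts for how well this change is accepted, and the result therefore shows only that the number holds, not the reason.

On these data alone, the methoxy and the fluorine entered together, so their separate contributions remain open, and a 2-methoxyphenyl or a 3-fluorophenyl group on its own would be needed to tell them apart. As far as these compounds go, it also remains open whether this position accepts a ring carrying a group of a different kind, such as an amine or a carboxylic acid.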